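This account rests on a few compounds, and the source may have more. Where it says the series, first, only, none or still open, it means among the compounds named here.

Compound 1 `CC(Oc1ccc(Oc2ccc(C(F)(F)F)cc2)cc1)C(=O)Cn1nnc(-c2ccccc2)n1` — in an ADME assay on S9 fraction from liver (Rattus norvegicus) for metabolic stability, read by LC-MS, using NADPH, with a stated time of 30 min (a lower number here means that less of the compound is left, a higher number that more of the compound is left), compound 1 gives 6%
Compound 2 `CC(Oc1ccc(Oc2ccc(Cl)cc2)cc1)C(=O)Cn1nnc(-c2ccc(C(=O)O)cc2)n1` — in this assay compound 2 gives 32%

Of these two numbers, compound 2 stands highest, and its gap to compound 1 lies beyond the scatter. Compound 3 `CC(Oc1ccc(Oc2ccc(C(F)(F)F)cc2)cc1)C(=O)Cn1nnc(-c2ccc(C(=O)O)cc2)n1` differs from compound 2 by trifluoromethyl in place of chloro on an aromatic carbon. Among the compounds with values here, no measured pair isolates this single change: compound 1 also carries the trifluoromethyl, yet differs from compound 2 in a second place as well. A modest downward step is expected, a number 10 percentage points lower from compound 2 to compound 3 (within the scatter), about the size of the scatter. Compound 3 is therefore estimated at 22% in this assay, within a range from 8% to 40%.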

Compound 3, percent of the compound remaining in the Rattus norvegicus assay: 36%
Compound 3: the middle estimate sits 14 percentage points below what was measured, and the stated range covers the measured number.
By their numbers in the Rattus norvegicus assay, from the lowest: compound 1; then compounds 2 and 3 (each within the scatter of the next).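

Within the data shown here, compounds 2 and 3 form the first pair that isolates this place: in the Rattus norvegicus assay compound 2 gives 32% and compound 3 gives 36% and the step of a number 4 percentage points higher from compound 2 to compound 3 (within the scatter) means that chloro and trifluoromethyl cannot be told apart here. In the Rattus norvegicus assay, the step of a number 30 percentage points higher from compound 1 to compound 3 (beyond the scatter) comes with carboxy in place of hydrogen on an aromatic carbon, with trifluoromethyl present in both compounds. In a physicochemical assay for lipophilicity, read by HPLC, tested at 5 mM (a lower number here means a more polar compound, a higher number a more lipophilic compound), compound 2 gives 3.3 and compound 3 gives 3.5 and the step of a number 0.20 log units higher from compound 2 to compound 3 (within the scatter) likewise separates neither group.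

Going by these compounds, how a methoxy or nitrile at this place, or an amine in place of the carboxy, would read stays open. No measurement shown here explains any of these numbers.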